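The source may report more compounds than this note shows. Statements on the series, on what has been measured and on what is new or still open speak of the compounds shown alone.

In a functional assay on LoVo cells (Homo sapiens) for inhibition, read by MTT assay, with a stated time of 24 h (on this read-out lower numbers stand for stronger inhibition and higher numbers for weaker inhibition), three compounds built on the same core have been measured, and they differ only in the aryl group on an aromatic nitrogen. Compound 1 `CC1(C)[C@H]2CC[C@]1(C)N(Cc1cn(-c3ccccc3Br)nn1)C(=O)C2`, with 2-bromophenyl, gives 60 nM, and compound 2 `CC1(C)[C@H]2CC[C@]1(C)N(Cc1cn(-c3ccc(C#N)cc3)nn1)C(=O)C2`, with 4-cyanophenyl, gives 90 nM. These two cannot be separated: a 1.5-fold higher number from compound 1 to compound 2 (0.18 log units; within the scatter). Compound 3 `CC1(C)[C@H]2CC[C@]1(C)N(Cc1cn(-c3cccc(O)c3)nn1)C(=O)C2`, with 3-hydroxyphenyl, gives 410 nM, the highest number of the three. It stands clearly apart from both of the others, as a 6.8-fold higher number from compound 1 to compound 3 (0.83 log units; beyond the scatter) and a 4.6-fold higher number from compound 2 to compound 3 (0.66 log units; beyond the scatter) show.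

Compound 4 `CC1(C)[C@H]2CC[C@]1(C)N(Cc1cn(-c3ccc(Cl)cc3)nn1)C(=O)C2` has not yet been measured. Going from compound 3 to compound 4 places 4-chlorophenyl in place of 3-hydroxyphenyl on an aromatic nitrogen. The two steps into compound 3 bear most directly on this change, since each replaces a non-hydroxylated aryl group with the same 3-hydroxyphenyl. Compound 4 reverses that kind of change, although its chlorine is found in neither compound 1 nor compound 2. A modest move toward a lower number is therefore expected, similar in size to those two steps: a 4.1-fold lower number from compound 3 to compound 4 (0.61 log units; beyond the scatter). The estimate for compound 4 is 100 nM, with an expected range from 40 nM to 300 nM.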

Compound 4, half-maximal inhibitory concentration: 160 nM
For compound 4 the middle estimate is 1.6-fold (0.20 log units) below the measured one; the measured number falls inside the stated range.
By their numbers in this assay, from the lowest: compounds 1, 2 and 4 (each within the scatter of the next, the first and the last beyond it); then compound 3.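

The step to the 4-chlorophenyl group, a 2.6-fold lower number from compound 3 to compound 4 (0.41 log units; beyond the scatter), gives a third aryl group without the hydroxyl that reads lower than the 3-hydroxyphenyl group in this assay, so among these four compounds, compound 3 stands apart from each of the others. Exchanging the substituent on the same phenyl group, a 1.8-fold higher number from compound 2 to compound 4 (0.25 log units; within the scatter), does not separate the chloro and cyano compounds, but the aryl groups without a hydroxyl are not wholly interchangeable, as the change from 2-bromophenyl, a 2.7-fold higher number from compound 1 to compound 4 (0.43 log units; beyond the scatter), exceeds the scatter even though compound 1 and compound 2 cannot be separated. No measurement offered here accounts for any of these differences.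

From the compounds shown here alone, the step from compound 3 to compound 4 changes both the substituent and its place on the phenyl group, so whether the higher number of compound 3 belongs to the hydroxyl or to its place remains open, a question that 4-hydroxyphenyl and 3-chlorophenyl groups would address. Going by these compounds, how an aminophenyl group, a carboxyphenyl group or a longer alkyl chain on this nitrogen would read in this assay also remains open.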